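This account rests on a few compounds, and the source may have more. Where it says the series, first, only, none or still open, it means among the compounds named here.

In an assay for inhibition of leukotriene C4 synthase (Homo sapiens), read by LC-MS, with stated times of 15 min and 30 min (on this read-out higher numbers stand for weaker inhibition and lower numbers for stronger inhibition), the measured compounds are:
compound 1, `COc1cc(N(CC2CC2)c2ccc(F)c3ccccc23)cnc1C(=O)[C@H]1C[C@@H]1C(=O)O`, which gives 0.758 nM;
compound 2, `COc1cc(N(CC(C)C)c2ccc(F)c3ccccc23)cnc1C(=O)[C@H]1C[C@@H]1C(=O)O`, which gives 0.381 nM;
compound 3, `COc1cc(N(CC2CC2)c2cccc(C(F)(F)F)c2)cnc1C(=O)[C@H]1C[C@@H]1C(=O)O`, which gives 6.42 nM.

Compound 2 differs from compound 1 by isopropyl in place of cyclopropyl on a saturated chain carbon bound to a nitrogen on an aromatic ring, and that change gave a 2.0-fold lower number from compound 1 to compound 2 (0.30 log units; within the scatter). Compound 4, `COc1cc(N(CC(C)C)c2cccc(C(F)(F)F)c2)cnc1C(=O)[C@H]1C[C@@H]1C(=O)O`, carries the same change on the core of compound 3: isopropyl in place of cyclopropyl on a saturated chain carbon bound to a nitrogen on an aromatic ring. How the core of compound 3 differs from that of compound 1 is not broken down here, but their two values show compound 3 giving the higher number, by a margin beyond the usual scatter. The change from cyclopropyl to isopropyl has been seen only once, so the expectation rests on that single step. For compound 4 the expected step is a 1.8-fold lower number from compound 3 to compound 4 (0.26 log units; within the scatter) because a 2.0-fold lower number from compound 1 to compound 2 (0.30 log units; within the scatter) stayed within the scatter. Compound 4 is therefore estimated at 3.5 nM, likely between 1.5 nM and 8 nM.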

Compound 4, half-maximal inhibitory concentration: 4.74 nM
Compound 4: the middle estimate sits 1.4-fold (0.13 log units) below what was measured; measured number inside the range.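

In this assay, isopropyl in place of cyclopropyl gave a 1.4-fold lower number from compound 3 to compound 4 (0.13 log units; within the scatter), so on this second core the change again stayed within the usual scatter. Set beside the earlier case, the two steps agree: the same change on two cores in this assay, a 2.0-fold lower number (0.30 log units; within the scatter) from compound 1 to compound 2 and a 1.4-fold lower number (0.13 log units; within the scatter) from compound 3 to compound 4, 1.5-fold (0.17 log units) apart, within the scatter of two such steps. On these two cores, then, the change carried over with little effect on the read-out, but two pairs cannot show that it would do so on other cores, nor can they explain why the steps are small.

From the compounds shown here alone, it remains open whether a longer chain or a chain ending in an amine, on that same saturated chain carbon, would behave like cyclopropyl and isopropyl. Going by these compounds, a core carrying a nitrile instead of trifluoromethyl also remains untested here as a further check on this transfer.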